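From 1H-indol-5-yl to 4-chloro-3-fluorophenyl on an amide-type nitrogen

This account rests on a few compounds, and the source may have more. Where it says the series, first, only, none or still open, it means among the compounds named here.

Three measured entries on a shared core frame this account: compound 1 (`O=C(Nc1ccc(Cl)cc1)[C@H]1CNC[C@@H]1C(=O)Nc1ccc(-n2ccccc2=O)cc1F`), compound 2 (`CCS(=O)(=O)N1C[C@H](C(=O)Nc2ccc(Cl)cc2)[C@@H](C(=O)Nc2ccc(-n3ccccc3=O)cc2F)C1`) and compound 3 (`CS(=O)(=O)N1C[C@H](C(=O)Nc2ccc3[nH]ccc3c2)[C@@H](C(=O)Nc2ccc(-n3ccccc3=O)cc2F)C1`). In a physicochemical assay for lipophilicity, at pH 7.4 (on this read-out higher numbers stand for higher lipophilicity and lower numbers for lower lipophilicity), compound 1 has the entry "not determined" (no result reported) and so offers no number for comparison. Compound 2 reads 2.44 on this scale, while compound 3 reads 1.07 on the same scale. Within the data shown here, compound 3 therefore holds the lower of the only two numbers available, and its gap to compound 2 lies beyond the scatter.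

Compound 4 (`CS(=O)(=O)N1C[C@H](C(=O)Nc2ccc(Cl)c(F)c2)[C@@H](C(=O)Nc2ccc(-n3ccccc3=O)cc2F)C1`) still awaits measurement. It differs from compound 3 by a single exchange on an amide-type nitrogen: 4-chloro-3-fluorophenyl in place of 1H-indol-5-yl on an amide-type nitrogen with 4-chloro-3-fluorophenyl in place of 1H-indol-5-yl. Among the measured compounds shown here, no measured pair shows this exchange on its own, so the forecast rests on little evidence. For the measured compounds named here, with compound 3 at 1.07 as the starting point and compound 2 at 2.44 as the only other number, a rise beyond the scatter is expected in this assay for the new compound. The expected change is a number 1.13 log units higher from compound 3 to compound 4 (beyond the scatter) in the upward direction. Compound 4 is estimated at 2.2 with an expected range from 1.75 to 2.65 on this scale.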

Compound 4, distribution coefficient: 2.37
Compound 4: middle estimate off by 0.17 log units, on the low side, within the range that was stated.
By their numbers in this assay, from the lowest: compound 3; then compounds 4 and 2 (each within the scatter of the next).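

In this assay, among these compounds, placing 4-chloro-3-fluorophenyl instead of 1H-indol-5-yl on the amide-type nitrogen gives a number 1.30 log units higher from compound 3 to compound 4 (beyond the scatter), a large step and the first in this set in which only one place changes. The earlier numbers came from compounds differing in more than one place, so their gap could not be assigned to any single group, whereas this step shows that the group on this nitrogen alone can move the read-out well beyond the scatter. The exchange removes a five-membered aromatic ring and the hydrogen-bond donor counted in 1H-indol-5-yl and brings in chlorine and fluorine, but no measurement here explains the size of the step.

Which of these differences carries the step stays open, and compound 2 cannot settle it, since it differs from compound 4 in more than one place. Also open is how the read-out would respond to an aminophenyl or a carboxyphenyl group on this amide-type nitrogen, where the set shown offers only 1H-indol-5-yl and halogen-bearing phenyl groups.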